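The source may hold more compounds than are shown below. What is called first, only, known or untested is meant among the compounds shown, and "the series" means these compounds.

Working notes on the series

Of the compounds shown here, three of the shared core have been measured in an in vitro functional assay on cells for agonist activity at Bombesin receptor subtype-3 (Homo sapiens), read by luminescence and calcium flux; on this read-out lower numbers stand for an effect already at smaller amounts and higher numbers for an effect only at larger amounts of compound. Compound 1 `CCCCc1cnc(CCc2ccc(-c3ccccc3C(=O)O)cc2)[nH]1` gives 2710 nM in this assay. Compound 2 `N#Cc1ccccc1Cc1cnc(CCc2ccc(-c3ccccc3C(=O)O)cc2)[nH]1` gives 5480 nM, and compound 3 `CC(C)(C)c1cnc(CCc2ccc(-c3ccccc3C(=O)O)cc2)[nH]1` gives 4330 nM. Between them the steps are a 2.0-fold higher number from compound 1 to compound 2 (0.31 log units; beyond the scatter), a 1.6-fold higher number from compound 1 to compound 3 (0.20 log units; within the scatter) and a 1.3-fold lower number from compound 2 to compound 3 (0.10 log units; within the scatter). Compound 3 therefore stands second highest of the three numbers, with compound 2 nearest and compound 1 furthest, both within the scatter of it.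

The next compound, compound 4 `COc1ccc(Cc2cnc(CCc3ccc(-c4ccccc4C(=O)O)cc3)[nH]2)cc1`, differs from compound 3 by 4-methoxybenzyl in place of tert-butyl on an aromatic carbon. Going by the values given here, two measured steps bear on this change. The step from compound 1 to compound 2 put an aryl-bearing chain in place of an alkyl chain and gave a 2.0-fold higher number from compound 1 to compound 2 (0.31 log units; beyond the scatter), a modest rise. The step from compound 2 to compound 3 exchanged a benzyl for a tert-butyl and gave a 1.3-fold lower number from compound 2 to compound 3 (0.10 log units; within the scatter), within the scatter. Returning from tert-butyl to a benzyl, now 4-methoxybenzyl, is expected to give a small step in this assay, a 1.2-fold higher number from compound 3 to compound 4 (0.06 log units; within the scatter), toward a higher number or none beyond the scatter, because of a 1.3-fold lower number from compound 2 to compound 3 (0.10 log units; within the scatter). Compound 4 is thus estimated at 5000 nM in this assay, with a range from 2500 nM to 10000 nM.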

Compound 4, half-maximal effective concentration: 5360 nM
Estimate against measurement, compound 4: 1.1-fold (0.03 log units) below; measured number inside the range.
By their numbers in this assay, from the lowest: compounds 1, 3, 4 and 2 (each within the scatter of the next, the first and the last beyond it).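

Putting 4-methoxybenzyl, with 9 heavy atoms and one six-membered aromatic ring of carbon only, in place of the 4 heavy atoms of tert-butyl gives a 1.2-fold higher number from compound 3 to compound 4 (0.09 log units; within the scatter) in this assay; at this aromatic carbon, then, a ring-bearing group and a branched alkyl group are not told apart by this read-out. Within the benzyl-type groups, 4-methoxyphenyl in place of 2-cyanophenyl gives a 1.0-fold lower number from compound 2 to compound 4 (0.01 log units; within the scatter), so the exchange of a nitrile at one ring position for a methoxy at another leaves no step to read. Against the butyl of compound 1, the new group gives a 2.0-fold higher number from compound 1 to compound 4 (0.30 log units; within the scatter), while the earlier aryl-bearing change gave a 2.0-fold higher number from compound 1 to compound 2 (0.31 log units; beyond the scatter), so the step beyond the scatter seen with the 2-cyanobenzyl group is not repeated with 4-methoxybenzyl, although the two steps are close in size. No available evidence bears on the reason for these steps.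

The compounds shown leave open whether an amine, a carboxylic acid or a longer chain at this aromatic carbon would give a step beyond the scatter from compound 3.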